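Furan-2-yl for pyridin-2-yl on the shared core

The source may report more compounds than this note shows. Statements on the series, on what has been measured and on what is new or still open speak of the compounds shown alone.

Compound 3 `Oc1cccc(-c2cc(-c3ccc(Cl)cc3)nc(-c3ccccn3)c2)c1` in a functional assay on T47D cells (Homo sapiens) for cytotoxicity, read by CCK-8 assay and cell counting, with a stated time of 2 days (a higher number here means a weaker inhibitor, a lower number a stronger inhibitor), gives 13900 nM. In this assay compound 1 `Oc1cccc(-c2cc(-c3ccc(Cl)cc3)nc(-c3cccs3)c2)c1` gives 10500 nM and compound 2 `Oc1cccc(-c2cc(-c3cccc(Cl)c3)nc(-c3ccco3)c2)c1` gives 3570 nM. Among these three numbers compound 3 stands highest; its gap to compound 1 is within the scatter, while its gap to compound 2 is beyond the scatter. Compound 4 `Oc1cccc(-c2cc(-c3ccc(Cl)cc3)nc(-c3ccco3)c2)c1` is not yet measured and differs from compound 3 in one place: furan-2-yl in place of pyridin-2-yl on an aromatic carbon. Within the data shown here, no measured step exchanges pyridin-2-yl for furan-2-yl directly. Among the measured compounds shown here, the only step at the same place, a 1.3-fold higher number from compound 1 to compound 3 (0.12 log units; within the scatter), put pyridin-2-yl in for thiophen-2-yl and stayed within the scatter, so exchanging one five-membered heteroaryl for a six-membered one left this assay much where it was. For the measured compounds named here, compound 2 also carries furan-2-yl but differs from compound 4 in another place, so its value shows only that a furan-2-yl compound of this series can give a lower number. The step of a 2.0-fold lower number from compound 3 to compound 4 (0.30 log units; within the scatter) is therefore expected to be modest, leaning toward a lower number, with wide uncertainty. Compound 4 is estimated at 7000 nM in this assay, within a range from 2500 nM to 20000 nM.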

Compound 4, half-maximal inhibitory concentration: 10500 nM
For compound 4 the middle estimate is 1.5-fold (0.18 log units) below the measured one; measured number inside the range.
By their numbers in this assay, from the lowest: compound 2; then compounds 1, 4 and 3 (each within the scatter of the next).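

Notes on the position next to the ring nitrogen: in this assay, with the 4-chlorophenyl group held fixed, furan-2-yl now joins the comparison through a 1.3-fold lower number from compound 3 to compound 4 (0.12 log units; within the scatter) and no change at the digits printed from compound 1 to compound 4 (within the scatter), both within the scatter. Pyridin-2-yl, thiophen-2-yl and furan-2-yl therefore cannot be placed in any order at this position, and neither the ring size nor the change of hetero atom among these three separates the compounds in this assay. With furan-2-yl held fixed, a 2.9-fold higher number from compound 2 to compound 4 (0.47 log units; beyond the scatter) is the first measured step at the chlorophenyl place and the only step shown beyond the scatter, so within this pair the chlorine position changes the number.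

On these data alone, whether that chlorine step also holds with thiophen-2-yl or pyridin-2-yl on the shared core remains open, as does the outcome of an amine such as piperidin-1-yl or a carboxylic acid at the position next to the ring nitrogen. Nothing available here accounts for the flat heteroaryl steps or for the chlorine step.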